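The compounds below may be only part of what the source reports. "The series", "measured", "known", "first", "only" and "open" are said of these compounds alone.

Working notes on the series. In an ADME assay on microsomes from liver (Rattus norvegicus) for metabolic stability (on this read-out higher numbers stand for a longer-lived compound and lower numbers for a shorter-lived compound), compound 1 `C/C(=C1/OC(=O)NC1=O)C(c1ccc(-c2ccc3cccc(F)c3c2)[nH]c1=O)C(C)C` gives > 3 h, which is a limit of the assay and not a number. Compound 2 `CCC(CC)C(/C=C1\OC(=O)NC1=O)c1ccc(-c2ccc3cccc(F)c3c2)[nH]c1=O` also gives only a limit in this assay, > 3 h. Compound 3 `Cc1cc(C(/C=C2\OC(=O)NC2=O)C(C)C)c(=O)[nH]c1-c1ccc2cccc(F)c2c1` likewise reaches a limit, > 3 h. All three values therefore sit at the limit of > 3 h in this assay, at which 3 of the 3 values shown sit, so compound 1 cannot be ranked against the others; it simply shares their position. Compound 4 `CC(C)C(c1ccc(-c2ccc3cccc(F)c3c2)[nH]c1=O)C1SC(=O)NC1=O` differs from compound 1 by a group of 7 heavy atoms (3 carbon, 1 nitrogen, 2 oxygen, 1 sulfur; one five-membered non-aromatic ring with 2 hetero atoms) in place of a group of 9 heavy atoms (5 carbon, 1 nitrogen, 3 oxygen; one five-membered non-aromatic ring with 2 hetero atoms), on a saturated chain carbon bound to an aromatic carbon and a saturated chain carbon. Going by the values given here, no measured step of this kind exists, and with every value at the limit no direction can be read from the data; a step no larger than the usual scatter is expected, a number no higher from compound 1 to compound 4 (the limit leaves the size open). Compound 4 is thus estimated at 3 h, between 1.5 h and 6 h, and will most likely again be reported only as a limit.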

Compound 4, half-life: 0.76 h
The estimate for compound 4 lay 3.9-fold (0.60 log units) above the measured number, outside the stated range (below it).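

In this assay the group on the saturated chain carbon bound to an aromatic carbon and a saturated chain carbon is not neutral: bringing in 2,4-dioxo-1,3-thiazolidin-5-yl gives an at least 3.9-fold lower number from compound 1 to compound 4 (0.59 log units; beyond the scatter). Compound 4 carries the only value shown that is a number and not a limit, and the others stay limits: the limit of > 3 h in this assay, at which 3 of the 4 values shown sit.

Going by these compounds alone, no pair separates the sulfur of the entering ring from the double bond outside aromatic rings that is lost with the change. On these data alone, how a carboxylic acid or an amine on this carbon would read remains open.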